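Trifluoromethoxy in place of chloro on the aromatic ring

A few compounds are considered here, and "the series" means these few. Any claim that something is new, unique, unknown or untested is made for them only; others in the source may bear on it.

- Compound 1 (`CS(=O)(=O)N1C(=O)COC12C=CC(=O)C=C2`) – > 10000 nM
- Compound 2 (`O=C1C=CC2(C=C1)OCC(=O)N2S(=O)(=O)c1ccc(Cl)cc1`) – 860 nM

Both values come from a functional assay on HepG2 cells (Homo sapiens) for inhibition, read by sulforhodamine B assay, with a stated time of 74 h (a higher number here means a weaker inhibitor, a lower number a stronger inhibitor), in this small set. For compound 1, > 10000 nM is a limit of the assay and not a number. For the measured compounds named here, compound 2 gives 860 nM as the only true number so far.

Compound 3 (`O=C1C=CC2(C=C1)OCC(=O)N2S(=O)(=O)c1ccc(OC(F)(F)F)cc1`) differs from compound 2 by a single change (trifluoromethoxy in place of chloro on an aromatic carbon) with trifluoromethoxy in place of chloro on an aromatic carbon.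

Going by the values given here, the one measured step is an at least 11-fold lower number from compound 1 to compound 2 (1.06 log units; beyond the scatter) with 4-chlorophenyl in place of methyl on a sulfonyl sulfur. Among the compounds with values here, it bears on the new change only indirectly: it exchanged the whole group on sulfur, and no measured pair exchanges the chloro itself. Compound 2 at 860 nM is the anchor, and compound 3 keeps its aromatic ring, so no step beyond the scatter is expected in this assay and neither direction is favoured.

The estimated step is a 1.1-fold lower number from compound 2 to compound 3 (0.03 log units; within the scatter) and carries wide uncertainty. For compound 3 the expected value is 800 nM with an estimated range from 250 nM to 2500 nM as its bounds.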

Compound 3, half-maximal inhibitory concentration: > 10000 nM
Compound 3 was reported as a limit; the forecaster's own chance of this, stated with the estimate: 3%; at least 12-fold (1.09 log units) between middle value and limit.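

In this assay, trifluoromethoxy in place of chloro on an aromatic carbon, para to a large group, gives an at least 11-fold higher number from compound 2 to compound 3 (1.06 log units; beyond the scatter), so the substituent at this position matters in this assay. The earlier step, an at least 11-fold lower number from compound 1 to compound 2 (1.06 log units; beyond the scatter), exchanged the whole group on the sulfonyl sulfur; this one shows that keeping the aromatic ring on sulfur does not by itself preserve the value of compound 2, and that a change on that ring alone can take the compound to the limit of the assay. The step can be read only as a minimum, and its full size remains unknown, because compound 3 is reported at a limit and not a number: the limit of > 10000 nM in this assay, at which 2 of the 3 values shown sit.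

The compounds shown leave open whether the value of compound 2 depends on chloro specifically, or whether fluoro, bromo, methyl, methoxy or a nitrile at the same position would also give a measurable number. They also leave open how trifluoromethoxy or chloro would behave on another carbon of the aromatic ring.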